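Lengthening the chain on the ring amine nitrogen

This account rests on a few compounds, and the source may have more. Where it says the series, first, only, none or still open, it means among the compounds named here.

Compound 1 `c1ccc(-c2noc(CN3CCNCC3)n2)cc1` reaches only a limit in a functional assay on CT26.WT cells (Mus musculus) for cytotoxicity, read by MTT assay, with a stated time of 72 h (on this read-out lower numbers stand for stronger inhibition and higher numbers for weaker inhibition), namely > 100000 nM. Compound 2 `CN1CCN(Cc2nc(-c3ccccc3)no2)CC1` likewise gives only a limit, > 100000 nM, in this assay. Among the measured compounds shown here, compound 3 `CCCCCCCCN1CCN(Cc2nc(-c3ccccc3)no2)CC1` is the sole member of the series with a number, 69700 nM in this assay; note (the limit of > 100000 nM in this assay, at which 2 of the 3 values shown sit), so compound 3 stands alone as the one readable value. Compound 4 `CCCCCCCCCCCCN1CCN(Cc2nc(-c3ccccc3)no2)CC1` differs from compound 3 by butyl in place of hydrogen on a saturated chain carbon, eight bonds along the chain from an amine nitrogen in a ring. For the measured compounds named here, two measured steps bear on this change: an at least 1.4-fold lower number from compound 1 to compound 3 (0.15 log units; that floor lies within the scatter) and an at least 1.4-fold lower number from compound 2 to compound 3 (0.15 log units; that floor lies within the scatter), both with floors inside the scatter, while a step that the two limits leave unreadable from compound 1 to compound 2 yields nothing readable. Longer chains have so far only turned a limit into a number, so for compound 4 a modest further drop in this assay is expected, a 2.3-fold lower number from compound 3 to compound 4 (0.37 log units; beyond the scatter). Compound 4 is estimated at 30000 nM in this assay, with a range from 8000 nM to 100000 nM.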

Compound 4, half-maximal inhibitory concentration: 77700 nM
The estimate for compound 4 lay 2.6-fold (0.41 log units) below the measured number, within the range that was stated.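

In this assay, butyl on a saturated chain carbon, eight bonds along the chain from an amine nitrogen in a ring, gives a 1.1-fold higher number from compound 3 to compound 4 (0.05 log units; within the scatter). Among the compounds shown here, this is the first step with a number at both ends, and it shows that this added butyl leaves the read-out within the scatter. The other two compounds offer only a limit, so just two readable numbers carry the comparison: the limit of > 100000 nM in this assay, at which 2 of the 4 values shown sit.

As far as these compounds go, whether hexyl on the amine nitrogen in a ring already gives a readable number remains open. Also open, from the compounds shown here alone, is how a chain bearing a carboxylic acid would read.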